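The compounds below may be only part of what the source reports. "The series", "measured", "known", "first", "only" and "open" are said of these compounds alone.

Measured in a functional assay on SH-SY5Y cells (Homo sapiens) for inhibition, read by MTT assay, with a stated time of 72 h; on this read-out lower numbers stand for stronger inhibition and higher numbers for weaker inhibition:
- compound 1 `CC(C)c1ccc(Nc2ccc(C(=O)C(Cl)Cl)cc2[N+](=O)[O-])cc1` gives 1000 nM
- compound 2 `CC(C)(C)c1ccc(Nc2ccc(C(=O)C(Cl)Cl)cc2[N+](=O)[O-])cc1` gives 1100 nM
- compound 3 `CC(C)(O)c1ccc(Nc2ccc(C(=O)C(Cl)Cl)cc2[N+](=O)[O-])cc1` gives 2300 nM

Compound 3 has the highest number of the three, which makes it the weakest inhibitor in this small set. Compound 4 `CC(C)(CO)c1ccc(Nc2ccc(C(=O)C(Cl)Cl)cc2[N+](=O)[O-])cc1` has not been measured yet. It has hydroxymethyl in place of hydroxy on a saturated chain carbon bound to an aromatic carbon and two saturated chain carbons. Within the data shown here, no measured step makes this exact change, so the nearest steps have to serve as a guide. Methyl in place of hydrogen gave a 1.1-fold higher number from compound 1 to compound 2 (0.04 log units; within the scatter) and so made no clear difference. The two hydroxy changes gave a 2.3-fold higher number from compound 1 to compound 3 (0.36 log units; beyond the scatter) and a 2.1-fold higher number from compound 2 to compound 3 (0.32 log units; beyond the scatter) and both are modest. With steps this small nearby, no change beyond the scatter is expected in this assay, perhaps only a slight drift towards a lower number. The expected step is a 1.3-fold lower number from compound 3 to compound 4 (0.11 log units; within the scatter) (an estimate only). The estimated value for compound 4 is 1800 nM (900 nM to 3700 nM).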

Compound 4, half-maximal inhibitory concentration: 1700 nM
Estimate against measurement, compound 4: 1.1-fold (0.02 log units) above, and the stated range covers the measured number.
By their numbers in this assay, from the lowest: compounds 1, 2, 4 and 3 (each within the scatter of the next, the first and the last beyond it).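

In this assay, hydroxymethyl in place of hydroxy on this saturated chain carbon gives a 1.4-fold lower number from compound 3 to compound 4 (0.13 log units; within the scatter), so the two groups cannot be told apart here. The earlier compounds shown here showed only a hydroxy directly on this carbon, with modest steps, whereas the hydroxymethyl group stays within the scatter of both groups without oxygen, with a 1.5-fold higher number from compound 2 to compound 4 (0.19 log units; within the scatter) and a 1.7-fold higher number from compound 1 to compound 4 (0.23 log units; within the scatter). Hydroxy in place of hydrogen, read at the two places on the chain, gives steps that agree within the scatter: the same change on two cores in this assay, a 2.3-fold higher number (0.36 log units; beyond the scatter) from compound 1 to compound 3 and a 1.5-fold higher number (0.19 log units; within the scatter) from compound 2 to compound 4, 1.5-fold (0.17 log units) apart, within the scatter of two such steps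

The compounds shown leave open how an amine, a carboxylic acid or a longer chain ending in hydroxy would read at this carbon in this assay. They also include no group here whose number lies beyond the scatter below that of compound 1.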